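Replacing piperidin-1-yl with a longer imidazole chain

The compounds below may be only part of what the source reports. "The series", "measured", "known", "first", "only" and "open" are said of these compounds alone.

Measured in a functional assay on SMMC-7721 cells (Homo sapiens) for antiproliferative activity, read by MTT assay, with a stated time of 48 h; a lower number here means a stronger inhibitor, a higher number a weaker inhibitor:
- compound 1 `Cn1cc(C2=C(c3nn(CCCn4cncn4)c4ncccc34)C(=O)NC2=O)c2ccccc21`: > 100000 nM (a limit of the assay, not a number)
- compound 2 `Cn1cc(C2=C(c3nn(CCCn4cccc4)c4ncccc34)C(=O)NC2=O)c2ccccc21`: > 100000 nM (a limit of the assay, not a number)
- compound 3 `Cn1cc(C2=C(c3nn(CCCN4CCCCC4)c4ncccc34)C(=O)NC2=O)c2ccccc21`: 7670 nM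

Among these three, compound 3 is the most potent and the only one with a true number, 7670 nM. Compound 4 `Cn1cc(C2=C(c3nn(CCCCn4ccnc4)c4ncccc34)C(=O)NC2=O)c2ccccc21` differs from compound 3 by this change: (1H-imidazol-1-yl)methyl in place of piperidin-1-yl on a saturated chain carbon, three bonds along the chain from an aromatic nitrogen. In words, (1H-imidazol-1-yl)methyl takes the place of piperidin-1-yl on a saturated chain carbon, three bonds along the chain from an aromatic nitrogen. Read one bond further out, 3-(piperidin-1-yl)propyl becomes 4-(1H-imidazol-1-yl)butyl.

Two large measured steps bear on this: an at least 13-fold lower number from compound 1 to compound 3 (1.11 log units; beyond the scatter) and an at least 13-fold lower number from compound 2 to compound 3 (1.11 log units; beyond the scatter). Both end at piperidin-1-yl and start from a five-membered aromatic ring, the kind of ring that compound 4 brings back. The step that the two limits leave unreadable from compound 1 to compound 2 adds little. Within the data shown here, no measured compound carries the longer chain, so the estimate stays wide. Compound 4 is therefore expected to give a higher number than compound 3 in this assay, by a step beyond the scatter, and it may reach the limit. The estimated change is a 6.5-fold higher number from compound 3 to compound 4 (0.81 log units; beyond the scatter). For compound 4 the expected value is 50000 nM, with an estimated range of 12000 nM to 100000 nM.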

Compound 4, half-maximal inhibitory concentration: 29200 nM
The estimate for compound 4 lay 1.7-fold (0.23 log units) above the measured number; the measured number falls inside the stated range.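

In this assay the five-membered aromatic rings of compound 1 and compound 2 had given only a limit of the assay, not a number: (the limit of > 100000 nM in this assay, at which 2 of the 4 values shown sit). Compound 4 shows that a five-membered aromatic ring at the end of a chain on this aromatic nitrogen can give a true number, and the size of its gain over the two limit compounds has only a lower bound (an at least 3.4-fold lower number from compound 2 to compound 4 (0.53 log units; beyond the scatter); an at least 3.4-fold lower number from compound 1 to compound 4 (0.53 log units; beyond the scatter)). Even so, the 4-(1H-imidazol-1-yl)butyl group does not match the 3-(piperidin-1-yl)propyl group, so the non-aromatic six-membered ring keeps its lead among the four compounds (a 3.8-fold higher number from compound 3 to compound 4 (0.58 log units; beyond the scatter)).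

Compound 4 changes the ring and the chain length together, so these compounds cannot show how much of its step belongs to each, and the 3-(1H-imidazol-1-yl)propyl and 4-(piperidin-1-yl)butyl groups would be the direct tests. Also open, going by these compounds, is whether other non-aromatic amines on this chain, such as morpholin-4-yl or pyrrolidin-1-yl, would follow compound 3 or compound 4.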